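This account rests on a few compounds, and the source may have more. Where it says the series, first, only, none or still open, it means among the compounds named here.

Measured so far in an assay on isolated protein for inhibition of Polyunsaturated fatty acid 5-lipoxygenase (Homo sapiens), read by HPLC, with a stated time of 15 min, in the presence of a further agent that is not named here; on this read-out higher numbers stand for weaker inhibition and lower numbers for stronger inhibition:
compound 1 `Cc1ccc(-c2cc(CCC(=O)N3CCN(Cc4ccc(C(C)(C)C)cc4)CC3)nn2-c2ccc(Cl)cc2)cc1`, 2900 nM
compound 2 `CC(C)(C)c1ccc(CN2CCN(C(=O)CCc3cc(-c4ccc(C(F)(F)F)cc4)n(-c4ccc(Cl)cc4)n3)CC2)cc1`, 8000 nM

Compound 2 gives the highest of the two numbers in this assay, the nearest being compound 1, which gives a lower number (a 2.8-fold higher number from compound 1 to compound 2 (0.44 log units; beyond the scatter)). Within the data shown here, that single measured step concerns trifluoromethyl in place of methyl on an aromatic carbon and is the only step available.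

Compound 3 `COc1ccc(-n2nc(CCC(=O)N3CCN(Cc4ccc(C(C)(C)C)cc4)CC3)cc2-c2ccc(C(F)(F)F)cc2)nn1` is not yet measured. It differs from compound 2 by 6-methoxypyridazin-3-yl in place of 4-chlorophenyl on an aromatic nitrogen. Among the measured compounds shown here, no measured step touches this place or this kind of exchange, so the step from compound 1 to compound 2 does not bear on it and gives no direction. For compound 3 the number in this assay is therefore expected near that of compound 2, as a step of no change at the digits printed from compound 2 to compound 3 (within the scatter), with a wide range. The estimate for compound 3 is 8000 nM, between 2000 nM and 32000 nM.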

Compound 3, half-maximal inhibitory concentration: 8000 nM
Estimate against measurement, compound 3: no gap at the digits printed; the range from low to high includes it.
By their numbers in this assay, from the lowest: compound 1; then compounds 2 and 3 (each within the scatter of the next).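

On the aromatic nitrogen, 6-methoxypyridazin-3-yl in place of 4-chlorophenyl gives no change at the digits printed from compound 2 to compound 3 (within the scatter) in this assay. Among these compounds, this is the first reading at this position, and it shows that a six-membered aromatic ring with 2 hetero atoms and 3 hydrogen-bond acceptors can replace a carbon-only aromatic ring with none, with no step beyond the scatter in this pair. No measurement on hand accounts for this result.

From the compounds shown here alone, whether the same exchange reads alike with the methyl of compound 1 in place of trifluoromethyl remains open, as this position has been read only with the 4-(trifluoromethyl)phenyl group present. Also open, going by these compounds, is how an aromatic ring carrying an amine or a carboxylic acid would read on this nitrogen.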